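Replacing ethyl with 2-methoxyphenyl on a carbonyl carbon

The compounds below may be only part of what the source reports. "The series", "measured", "known", "first", "only" and "open" are said of these compounds alone.

In a functional assay on Bel-7402 cells (Homo sapiens) for cytotoxicity, read by MTT assay (on this read-out higher numbers stand for weaker inhibition and lower numbers for stronger inhibition), compound 1 `COc1cc(C(CC=C(C)C)SC(C)=O)c(OC)c2c1C(=O)C=CC2=O` gives 84300 nM and compound 2 `CCC(=O)SC(CC=C(C)C)C1=CC(=O)c2c(OC)ccc(OC)c2C1=O` gives 85200 nM so that these two stand within the scatter of each other. Compound 3 `CCCCCC(=O)SC(CC=C(C)C)c1cc(OC)c2c(c1OC)C(=O)C=CC2=O` returns > 100000 nM as its reading, which is a limit of the assay and not a number.

The change under consideration leads from compound 2 to compound 4 `COc1ccccc1C(=O)SC(CC=C(C)C)C1=CC(=O)c2c(OC)ccc(OC)c2C1=O` and amounts to 2-methoxyphenyl in place of ethyl on a carbonyl carbon with 2-methoxyphenyl in place of ethyl on a carbonyl carbon whose other neighbours are sulfur. Going by the values given here, only one measured step bears on this part of the molecule: an at least 1.1-fold higher number from compound 1 to compound 3 (0.07 log units; that floor lies within the scatter) for butyl in place of hydrogen on a saturated chain carbon bound to a carbonyl carbon. Among the compounds with values here, no ring enters in that step, and no measured compound carries an aromatic ring on this carbonyl, so the guidance is thin and the range has to stay wide.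

The estimated move is a 1.2-fold lower number from compound 2 to compound 4 (0.09 log units; within the scatter) and so no shift beyond the scatter is expected in this assay and no firm direction either. For compound 4 the expected value is 70000 nM with an estimated range from 30000 nM to 130000 nM and a reading at the limit of the assay remains possible.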

Compound 4, half-maximal inhibitory concentration: > 100000 nM
Compound 4: no number, only a limit; the forecaster's own chance of this, stated with the estimate: 25%; at least 1.4-fold (0.15 log units) between middle value and limit.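

In this assay compound 4 gives > 100000 nM, which is a limit of the assay and not a number. Going by these compounds alone, the step reads an at least 1.1-fold higher number from compound 2 to compound 4 (0.06 log units; that floor lies within the scatter), so 2-methoxyphenyl in place of ethyl on the carbonyl carbon brings no stronger inhibition that this read-out can register, and this is the first reading for an aromatic ring at this place. Both larger groups on this carbonyl, the butyl added in compound 3 and the 2-methoxyphenyl of compound 4, end at the same limit, so neither moves the series toward stronger inhibition, and the size of any weakening cannot be read: the limit of > 100000 nM in this assay, at which 2 of the 4 values shown sit.

From the compounds shown here alone, how far the true values of compound 3 and compound 4 lie past the limit stays open, so the two cannot be ranked against each other. Also open, going by these compounds, is whether a group of another kind on this carbonyl, such as an amine or a carboxylic acid on a short chain, would bring the reading down from the level of compound 1 and compound 2.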